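A few compounds are considered here, and "the series" means these few. Any claim that something is new, unique, unknown or untested is made for them only; others in the source may bear on it.

Measured so far in a functional assay on MOLT-4 cells (Homo sapiens) for antiproliferative activity, with a stated time of 48 h; a lower number here means a stronger inhibitor, a higher number a weaker inhibitor:
- compound 1 `C=C(Br)C(=O)Nc1ccc(C(=O)/C=C/c2ccc(OC)cc2)cc1`: 610 nM
- compound 2 `C=C(Br)C(=O)Nc1ccc(C(=O)/C=C/c2ccc(N(C)C)cc2)cc1`: 1300 nM

Going by the values given here, compound 2, at 1300 nM, holds the higher of the two numbers, and its only neighbour is compound 1 at 610 nM. Among the compounds with values here, the single measured step, with dimethylamino in place of methoxy on an aromatic carbon, is modest: a 2.1-fold higher number from compound 1 to compound 2 (0.33 log units; beyond the scatter).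

The next compound is compound 3 `CN(C)c1ccc(/C=C/C(=O)c2ccc(N)cc2)cc1`, which has hydrogen in place of (1-bromoethenyl)carbonyl on a nitrogen on an aromatic ring. The measured step bears on this only loosely. Within the data shown here, it concerns a different place, and both measured compounds keep the (1-bromoethenyl)carbonyl, so no measurement yet shows what losing it does. The structural change is far larger than the one behind a 2.1-fold higher number from compound 1 to compound 2 (0.33 log units; beyond the scatter), so a larger step to a higher number in this assay is expected, on judgement rather than on a direct precedent. The expected move is a 9.2-fold higher number from compound 2 to compound 3 (0.97 log units; beyond the scatter), beyond the scatter. For compound 3 the estimated value is 12000 nM, with an expected range of 3000 nM to 50000 nM.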

Compound 3, half-maximal inhibitory concentration: 9900 nM
Compound 3: the middle estimate sits 1.2-fold (0.08 log units) above what was measured; low and high end bracket the measured number.
By their numbers in this assay, from the lowest: compound 1; then compound 2; then compound 3.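

With dimethylamino held constant, the nitrogen on the aromatic ring now has its first measured change: in this assay, hydrogen in place of (1-bromoethenyl)carbonyl gives a 7.6-fold higher number from compound 2 to compound 3 (0.88 log units; beyond the scatter), a wider step than a 2.1-fold higher number from compound 1 to compound 2 (0.33 log units; beyond the scatter) seen on the other side of the molecule. Compound 3, which carries the plain amino group, still gives a measured number of 9900 nM, so in this single pair the (1-bromoethenyl)carbonyl group is linked to a stronger result but is not needed for a measurable one. Nothing at hand explains the size of this step or shows how the group acts in these cells.

The compounds shown do not separate the contribution of the bromine from that of the rest of the (1-bromoethenyl)carbonyl group, a question that an acetyl or unbrominated propenoyl group on the same nitrogen would address. Whether the step carries over to the methoxy side of the series also stays open, as this change is shown only with dimethylamino in place.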